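The source may report more compounds than this note shows. Statements on the series, on what has been measured and on what is new or still open speak of the compounds shown alone.

Measured so far in a functional assay on DU-145 cells (Homo sapiens) for antiproliferative activity, read by sulforhodamine B assay, with a stated time of 48 h; on this read-out higher numbers stand for weaker inhibition of growth and lower numbers for stronger inhibition of growth:

Compound 1 (`COc1ccc(Nc2nc(NCCCO)c3ccccc3n2)cc1`) : 18300 nM
Compound 2 (`Nc1ccc(Nc2nc(NCCCO)c3ccccc3n2)cc1`) : 20800 nM

Among the measured compounds shown here, compound 2, at 20800 nM here, lies within the scatter of compound 1, at 18300 nM, and these are the only two measured compounds. Compound 3 (`OCCCNc1nc(Nc2ccc(F)cc2)nc2ccccc12`) differs from compound 2 by fluoro in place of amino on an aromatic carbon. For the measured compounds named here, one measured step bears on this change, amino in place of methoxy on an aromatic carbon (a 1.1-fold higher number from compound 1 to compound 2 (0.06 log units; within the scatter)). Going by the values given here, no measured compound carries fluoro, so that step is only a loose guide. Going by it, no step beyond the scatter is expected in this assay, and neither direction is favoured. Compound 3 is expected at 19000 nM (estimated range 9000 nM to 40000 nM). The estimated change is small (a 1.1-fold lower number from compound 2 to compound 3 (0.04 log units; within the scatter)).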

Compound 3, concentration for 50% growth inhibition: 20600 nM
The estimate for compound 3 lay 1.1-fold (0.04 log units) below the measured number; the range from low to high includes it.
By their numbers in this assay, from the lowest: compounds 1, 3 and 2 (each within the scatter of the next).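

In this assay, fluoro in place of amino on the aromatic carbon para to a large group gives a 1.0-fold lower number from compound 2 to compound 3 (0.00 log units; within the scatter), and fluoro in place of methoxy at the same place gives a 1.1-fold higher number from compound 1 to compound 3 (0.05 log units; within the scatter). The position has now carried three different groups, methoxy, amino and fluoro, and the read-out does not separate them, even though the step from amino to fluoro removes a hydrogen-bond donor and a hydrogen-bond acceptor by count. No evidence is available on why these three compounds read alike.

On these data alone, it remains open whether a carboxylic acid or a morpholine at this position would shift the number beyond the scatter. As far as these compounds go, the side chain on the shared core is the same in all three compounds, so the effect of a longer chain there, or of an amine in place of its hydroxyl, also remains open.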